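The compounds below may be only part of what the source reports. "The series", "measured", "known", "first", "only" and "open" are said of these compounds alone.

Measured compounds:
compound 1 `CN1C/C(=C\c2ccc(Br)cc2)C(=O)[C@]2(C1)[C@@H](c1ccc(Br)cc1)CN(C)[C@@]21C(=O)Nc2ccccc21` — 77.7%
compound 2 `CN1C/C(=C\c2ccc(Br)cc2)C(=O)[C@]2(C1)[C@@H](c1ccc(Br)cc1)CN(C)[C@@]21C(=O)N(C)c2ccccc21` — 53.5%
compound 3 `CN1C/C(=C\c2ccc(-c3cccs3)cc2)C(=O)[C@]2(C1)[C@@H](c1ccc(-c3cccs3)cc1)CN(C)[C@@]21C(=O)Nc2ccccc21` — 68%

All three were tested in a functional assay on the whole organism (strain Wister albino) for inhibition, with Rattus norvegicus as the target, read by paw edema, with a stated time of 1 h, at a dose of 50 mg/kg by the intraperitoneal route; on this read-out higher numbers stand for more inhibition at the one dose given (going by the name of the read-out) and lower numbers for less inhibition. Compound 2 differs from compound 1 by methyl in place of hydrogen on an amide-type nitrogen in a ring and this step gave a number 24.2 percentage points lower from compound 1 to compound 2 (beyond the scatter). Compound 3 carries a different core; the difference between the core of compound 1 and the core of compound 3 is not broken down here. Compound 3 and compound 1 give numbers within the scatter of each other in this assay, while compound 3 stands beyond the scatter from compound 2.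

Compound 4 `CN1C/C(=C\c2ccc(-c3cccs3)cc2)C(=O)[C@]2(C1)[C@@H](c1ccc(-c3cccs3)cc1)CN(C)[C@@]21C(=O)N(C)c2ccccc21` is not yet measured. It differs from compound 3 by methyl in place of hydrogen on an amide-type nitrogen in a ring, the same change as from compound 1 to compound 2. Because the earlier step was a number 24.2 percentage points lower from compound 1 to compound 2 (beyond the scatter), a step of like size is expected for compound 4, a number 24 percentage points lower from compound 3 to compound 4 (beyond the scatter). The estimate for compound 4 in this assay is 44%, between 30% and 58%.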

Compound 4, a percentage reported as inhibition, in the whole organism at one dose (the size of the read-out at that dose, not a potency): 84.7%
The estimate for compound 4 lay 40.7 percentage points below the measured number; measured number above the stated range.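

In this assay, methyl in place of hydrogen on an amide-type nitrogen in a ring gives a number 16.7 percentage points higher from compound 3 to compound 4 (beyond the scatter), so the step measured on the core of compound 1 does not carry over to the core of compound 3 in size or direction: the same change on two cores in this assay, a number 24.2 percentage points lower (beyond the scatter) from compound 1 to compound 2 and a number 16.7 percentage points higher (beyond the scatter) from compound 3 to compound 4, 40.9 percentage points apart, beyond the scatter of two such steps.

The outcome of this change therefore depends on the core in these two pairs. They do not show which feature of the cores decides the direction, and two pairs give no rule for any other core.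

From the compounds shown here alone, it remains open how a longer chain, such as ethyl, on that nitrogen would behave on either core. The same applies to a chain ending in an amine or a carboxylic acid.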